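Swapping Fluoro for Methyl on an Aromatic Ring

The source may report more compounds than this note shows. Statements on the series, on what has been measured and on what is new or still open speak of the compounds shown alone.

In an assay on HEK293 cells for positive allosteric modulation of metabotropic glutamate receptor 5 (Homo sapiens), read by FLIPR (on this read-out higher numbers stand for an effect only at larger amounts of compound and lower numbers for an effect already at smaller amounts), the measured compounds gave:

Compound 1 `Cc1ccc(S(=O)(=O)N2CC(c3nc(-c4cccc(Cl)c4)no3)C2)cc1`: > 10000 nM
Compound 2 `O=S(=O)(c1ccc(F)cc1)N1CC(c2nc(-c3cccc(Cl)c3)no2)C1`: > 10000 nM
Compound 3 `O=C(C1CCC(C(F)(F)F)CC1)N1CC(c2nc(-c3cccc(F)c3)no2)C1`: 680 nM.

For compound 1 the result is a limit of the assay, not a number. For compound 2 the result is likewise a limit. The change methyl in place of fluoro on an aromatic carbon gives a step that the two limits leave unreadable from compound 2 to compound 1; its size cannot be read because both values sit at the limit of > 10000 nM in this assay, at which 2 of the 3 values shown sit. How the cores of compound 3 and compound 2 differ is not broken down here. The unmeasured compound 4 `Cc1cccc(-c2noc(C3CN(C(=O)C4CCC(C(F)(F)F)CC4)C3)n2)c1` differs from compound 3 by methyl in place of fluoro on an aromatic carbon. This is the same kind of change as from compound 2 to compound 1, but the place differs: there the group sits para to a large group, here meta to a large group. With no readable measured step, the expectation rests on compound 3 alone. Compound 4 is expected at 600 nM, between 200 nM and 2000 nM. The expected step is a 1.1-fold lower number from compound 3 to compound 4 (0.05 log units; within the scatter), kept small because compound 3 gives 680 nM and nothing measured argues for a shift.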

Compound 4, half-maximal effective concentration: 1000 nM
For compound 4 the middle estimate is 1.7-fold (0.22 log units) below the measured one, within the range that was stated.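

In this assay, methyl in place of fluoro gives a 1.5-fold higher number from compound 3 to compound 4 (0.17 log units; within the scatter), so on this core the swap leaves no readable difference. The same kind of change on the other core, from compound 2 to compound 1, cannot be read, because both compounds stand at a limit of the assay and not at a number: the limit of > 10000 nM in this assay, at which 2 of the 4 values shown sit. Among the compounds shown here, with only one readable step, the series shows that the swap is tolerated on the core of compound 3, but not whether that result carries over to another core.

Still open, going by these compounds, is how a larger or different group on that aromatic carbon, such as a methoxy group, a nitrile or an amine, would read. Also open, on these data alone, is whether any such group would give a step beyond the scatter.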